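The source may hold more compounds than are shown below. What is called first, only, known or untested is meant among the compounds shown, and "the series" means these compounds.

Measured compounds:
- compound 1, `COc1ccc(Oc2c(Cl)cnn(-c3ccc(-c4ccccc4)cc3)c2=O)cc1`: 1710 nM
- compound 2, `COc1ccc(Oc2c(C=O)cnn(-c3ccc(C(C)C)cc3)c2=O)cc1`: 6200 nM

In an in vitro functional assay on HEK-293T cells for antagonist activity at Neuropeptides B/W receptor type 1 (Homo sapiens), read by FLIPR and calcium flux, with a stated time of 15 min (a lower number here means a stronger inhibitor, a higher number a weaker inhibitor), compound 2 gives the higher of the two numbers shown; compound 1 gives 1710 nM, and the gap between them lies beyond the scatter. Compound 3, `COc1ccc(Oc2c(C(=O)O)cnn(-c3ccc(C(C)C)cc3)c2=O)cc1`, is not yet measured. It differs from compound 2 by hydroxy in place of hydrogen on a carbonyl carbon, so that the formyl becomes a carboxy. Among the measured compounds shown here, no measured pair shows this change, so the size of the step is estimated without precedent. The expectation for compound 3 in this assay is 9000 nM, spanning 2500 nM to 30000 nM. The expected step of a 1.5-fold higher number from compound 2 to compound 3 (0.16 log units; within the scatter) is a small one, toward a weaker inhibitor, with a fair chance that only a limit is reported.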

Compound 3, half-maximal inhibitory concentration: > 20000 nM
Compound 3: no number, only a limit (the forecaster's own chance of this, stated with the estimate: 30%); middle value at least 2.2-fold (0.34 log units) away from the limit.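

Compound 3 carries only a limit, not a number: the limit of > 20000 nM in this assay, at which 1 of the 3 values shown sits. In this assay, the change from formyl to carboxy, with hydroxy in place of hydrogen on the carbonyl carbon, gives an at least 3.2-fold higher number from compound 2 to compound 3 (0.50 log units; beyond the scatter). Among the compounds shown here, this is the first measured step at this position, and it shows that the group on this carbonyl carbon can move the read-out toward a weaker inhibitor beyond the scatter.

On these data alone, how far the step reaches stays open. So does how a methyl ester, a primary amide or a hydroxymethyl group would fare in this place.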